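Swapping nitro for methoxy on the ester aryl ring

This account rests on a few compounds, and the source may have more. Where it says the series, first, only, none or still open, it means among the compounds named here.

Measured so far:
compound 1, `COc1cccc(C(=O)Oc2cc3c(C)ccc(C(C)C)c3cc2C)c1`: 12.5%
compound 2, `Cc1cc2c(C(C)C)ccc(C)c2cc1OC(=O)c1ccc([N+](=O)[O-])cc1`: 100%

Both compounds are esters of the same core, differing only in the aromatic ring attached to the carbonyl carbon. In a functional assay on PC-3 cells (Homo sapiens) for antiproliferative activity, read by sulforhodamine B assay, with a stated time of 48 h, tested at 50 uM (on this read-out higher numbers stand for more inhibition at the one concentration tested (going by the name of the read-out) and lower numbers for less inhibition), compound 1 gives 12.5%, and compound 2 gives 100%, the highest of the numbers shown. Within the data shown here, the single measured step, a number 87.5 percentage points higher from compound 1 to compound 2 (beyond the scatter), puts 4-nitrophenyl in place of 3-methoxyphenyl on the carbonyl carbon and is far beyond the scatter.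

Compound 3, `COc1ccc(C(=O)Oc2cc3c(C)ccc(C(C)C)c3cc2C)cc1`, has not yet been tested in this assay. Its structure differs from compound 2 by methoxy in place of nitro on an aromatic carbon, so the aryl ring changes from 4-nitrophenyl to 4-methoxyphenyl. The step from compound 1 to compound 2 bears on this directly, since it exchanges a methoxyphenyl for a nitrophenyl, though it also moves the group on the ring; the two differences cannot be separated with only these compounds. Because the gain in a number 87.5 percentage points higher from compound 1 to compound 2 (beyond the scatter) came with the nitro group, its removal is expected to cost much of that inhibition, and compound 3 is estimated at 25% (range 5% to 65%), a step of a number 75 percentage points lower from compound 2 to compound 3 (beyond the scatter).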

Compound 3, a percentage reported as inhibition, at one concentration (the size of the read-out at that concentration, not a potency): 10.4%
The estimate for compound 3 lay 14.6 percentage points above the measured number, within the range that was stated.
By their numbers in this assay, from the lowest: compounds 3 and 1 (each within the scatter of the next); then compound 2.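

Compound 3 keeps the substituent at the same ring position as in compound 2, so in this assay the step of a number 89.6 percentage points lower from compound 2 to compound 3 (beyond the scatter) isolates the exchange of nitro for methoxy, which the earlier comparison had mixed with a move of the group on the ring. The step of a number 2.1 percentage points lower from compound 1 to compound 3 (within the scatter) shows that the 4-methoxyphenyl and 3-methoxyphenyl esters cannot be told apart on this read-out, so among these three compounds, high inhibition is found only with the 4-nitrophenyl ester. No measurement is available here to explain why the nitro compound stands apart from the two methoxy compounds.

Going by these compounds, it remains open whether an amine, a nitrile or a carboxylic acid in place of the nitro group would retain the inhibition seen with compound 2 at 100%, and whether a 3-nitrophenyl ester would do so. Since the read-out reports a single concentration, these compounds also leave open how compound 2 would behave at lower concentrations, and so what its potency is.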